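Fluoro Added to a Series That Shows Only Assay Limits

This account rests on a few compounds, and the source may have more. Where it says the series, first, only, none or still open, it means among the compounds named here.

Compound 1 `COc1cc2nc(Nc3ccc(S(C)(=O)=O)cc3)nc(OC3CCN(C(=O)OC(C)(C)C)CC3)c2cc1OC`: > 10000 nM, a limit of the assay.
Compound 2 `COc1cc2nc(Nc3ccc(S(C)(=O)=O)cc3F)nc(OCC3CCN(C(=O)OC(C)(C)C)CC3)c2cc1OC`: > 10000 nM, a limit of the assay.
Compound 3 `COc1cc2nc(OC3CCN(C(=O)OC(C)(C)C)CC3)nc(Nc3ccc(S(C)(=O)=O)cc3)c2cc1OC`: > 10000 nM, a limit of the assay.

For the measured compounds named here, in a functional assay on HEK293 cells for agonist activity at Glucose-dependent insulinotropic receptor (Homo sapiens), read by cAMP accumulation, with a stated time of 60 min (a higher number here means that more compound is needed for the effect, a lower number that less compound is needed), no measured compound gave a number. Compound 3 stands at > 10000 nM, which is a limit and not a measured potency. Compound 1 sits at > 10000 nM, also a limit. Compound 2 shows only > 10000 nM, again a limit. This is summed up as the limit of > 10000 nM in this assay, at which 3 of the 3 values shown sit. Compound 3 therefore cannot be ranked against the other two; all three share the same limit.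

Compound 4 `COc1cc2nc(OC3CCN(C(=O)OC(C)(C)C)CC3)nc(Nc3ccc(S(C)(=O)=O)cc3F)c2cc1OC` differs from compound 3 by fluoro in place of hydrogen on an aromatic carbon, in words: fluoro in place of hydrogen on an aromatic carbon. Going by the values given here, no step between measured compounds exists to size this change. Compound 2, which carries the 2-fluoro-4-(methylsulfonyl)phenyl group on a differently built core, also shows only a limit. The step that the limit leaves unreadable from compound 3 to compound 4 is expected to be small, with no direction beyond the scatter. Compound 4 is expected to give 15000 nM, between 5000 nM and 50000 nM, most likely reported again as a limit.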

Compound 4, half-maximal effective concentration: > 10000 nM
Compound 4 gave a limit, no number; the forecaster's own chance of this, stated with the estimate: 85%; the middle value is on the limit's open side.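

For the compounds shown here, compound 3 and compound 4 both sit at a limit of the assay and not at a measured number, so no step between them can be read. Left open is how much of any of these compounds is needed for the effect in this assay, and whether the fluoro changes that at all, with every value resting on one limit: the limit of > 10000 nM in this assay, at which 4 of the 4 values shown sit.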